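The compounds below may be only part of what the source reports. "The series", "measured", "known", "first", "only" and "open" are said of these compounds alone.

Measured compounds:
- compound 1 `CC1(C)C[C@H](CN([C@H](CCC(F)(F)F)C(N)=O)S(=O)(=O)c2ccc(Cl)cc2)O1`: 3.8
- compound 2 `NC(=O)[C@@H](CCC(F)(F)F)N(C[C@H]1CCCOC1)S(=O)(=O)c1ccc(Cl)cc1`: 3.6

In a physicochemical assay for lipophilicity, read by HPLC, measured as octanol-water partition, at pH 7.4 (a lower number here means a more polar compound, a higher number a more lipophilic compound), compound 2 gives 3.6, which is within the usual scatter of compound 1 at 3.8. Compound 3 `NC(=O)[C@@H](CCC(F)(F)F)N(CC1CCOCC1)S(=O)(=O)c1ccc(Cl)cc1` has the same atoms as compound 2, joined differently: oxan-4-yl in place of oxan-3-yl on a saturated chain carbon bound to a sulfonamide nitrogen. It carries oxan-4-yl in place of oxan-3-yl on a saturated chain carbon bound to a sulfonamide nitrogen. Going by the values given here, no measured pair makes this exact swap. Among the compounds with values here, the only measured step at this place is a number 0.20 log units lower from compound 1 to compound 2 (within the scatter), so no change beyond the scatter is expected, and the estimated step is a number 0.10 log units lower from compound 2 to compound 3 (within the scatter). For compound 3 the estimated value is 3.5, with an expected range of 3.2 to 3.8.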

Compound 3, distribution coefficient: 3.5
Compound 3: middle estimate and measured number agree at the digits printed, within the range that was stated.
By their numbers in this assay, from the lowest: compounds 3, 2 and 1 (each within the scatter of the next).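

Oxan-4-yl in place of oxan-3-yl on a saturated chain carbon bound to a sulfonamide nitrogen gives a number 0.10 log units lower from compound 2 to compound 3 (within the scatter) in this assay and shows that joining the same atoms differently here has no effect that can be told from the scatter. The step to the oxetane-bearing compound, a number 0.30 log units lower from compound 1 to compound 3 (within the scatter) in this assay, also stays within the scatter, so these three groups cannot be separated by this measurement. Nothing available explains these numbers.

Still open, going by these compounds, is whether an amine or a carboxylic acid at this position would give a number beyond the scatter.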